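From benzyloxy to methoxy: a step still unmeasured

This account rests on a few compounds, and the source may have more. Where it says the series, first, only, none or still open, it means among the compounds named here.

In a functional assay on HepG2 cells (Homo sapiens) for cytotoxicity, read by spectrophotometry, with a stated time of 72 h (on this read-out lower numbers stand for stronger inhibition and higher numbers for weaker inhibition), compound 1 `COc1cc(-n2c(-c3cccc(O)c3)cccc2=O)cc(OC)c1OC` gives 34 nM. Compound 2 `COc1ccc(-n2c(-c3cc(OC)c(OC)c(OC)c3)cccc2=O)cc1OCc1ccccc1` gives 3040 nM, the higher of the two numbers and beyond the usual scatter, which makes it the weaker inhibitor of this pair. Compound 3 `COc1ccc(-n2c(-c3cc(OC)c(OC)c(OC)c3)cccc2=O)cc1OC` has not yet been measured. It departs from compound 2 in one place: hydrogen in place of phenyl on a saturated chain carbon bound to an oxygen on an aromatic ring. This puts hydrogen in place of phenyl on a saturated chain carbon bound to an oxygen on an aromatic ring, so benzyloxy becomes methoxy. Going by the values given here, no measured pair shows this change alone, so the expectation remains loose. In this assay, a moderate move toward stronger inhibition, beyond the scatter, is expected, with an estimated step of a 5.1-fold lower number from compound 2 to compound 3 (0.70 log units; beyond the scatter). The estimate for compound 3 is 600 nM, with an expected range from 80 nM to 3000 nM.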

Compound 3, half-maximal inhibitory concentration: 4870 nM
Estimate against measurement, compound 3: 8.1-fold (0.91 log units) below; measured number above the stated range.
By their numbers in this assay, from the lowest: compound 1; then compounds 2 and 3 (each within the scatter of the next).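

In this assay the exchange of benzyloxy for methoxy amounts to a 1.6-fold higher number from compound 2 to compound 3 (0.20 log units; within the scatter) and so gives no difference that this read-out can resolve. On a saturated chain carbon bound to an oxygen on an aromatic ring, phenyl and hydrogen therefore cannot be told apart here. The high number of compound 2 thus does not depend on its phenyl, since compound 3 lacks that ring and still falls within the scatter of it.

As far as these compounds go, whether a hydroxyl, an amine or a carboxylic acid at this place would also stay within the scatter remains open, as does what separates these two compounds from compound 1, which differs from them in more than one place. Nothing at hand offers an explanation for the outcome of this step.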